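The compounds below may be only part of what the source reports. "The series", "measured", "known", "first", "only" and "open" are said of these compounds alone.

For the measured compounds named here, compound 1 `COc1ccc(C2SCC(=O)N2NC(=O)CN2C(=O)c3ccccc3C2=O)cc1OC` gives 2.78 in a physicochemical assay for lipophilicity, in phosphate buffer, measured as octanol-water partition, with a stated time of 24 h (on this read-out lower numbers stand for lower lipophilicity and higher numbers for higher lipophilicity), the highest of the two numbers so far. Compound 2 `O=C(CN1C(=O)c2ccccc2C1=O)NN1C(=O)CSC1c1ccc(Cl)cc1Cl` gives 2.54 in this assay, and the step of a number 0.24 log units lower from compound 1 to compound 2 (within the scatter) sits within the scatter. Compound 3 `O=C(CN1C(=O)c2ccccc2C1=O)NN1C(=O)CSC1c1c[nH]c2ccccc12` differs from compound 1 by 1H-indol-3-yl in place of 3,4-dimethoxyphenyl on a saturated ring carbon. Going by the values given here, the only measured step, 2,4-dichlorophenyl in place of 3,4-dimethoxyphenyl on a saturated ring carbon, stayed within the scatter, so for a second exchange at the same saturated ring carbon no shift beyond the scatter is expected in this assay. For compound 3 the estimate is 2.8, range 2.3 to 3.3, an expected step of a number 0.02 log units higher from compound 1 to compound 3 (within the scatter).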

Compound 3, partition coefficient: 1.59
The estimate for compound 3 lay 1.21 log units above the measured number; measured number below the stated range.
By their numbers in this assay, from the lowest: compound 3; then compounds 2 and 1 (each within the scatter of the next).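

In this assay the saturated ring carbon proves sensitive to the group it carries: 1H-indol-3-yl gives a number 1.19 log units lower from compound 1 to compound 3 (beyond the scatter) and also a number 0.95 log units lower from compound 2 to compound 3 (beyond the scatter). The exchange between 3,4-dimethoxyphenyl and 2,4-dichlorophenyl therefore did not show the full reach of this position, and compound 3 now stands apart from compounds 1 and 2. Nothing available bears on the origin of this step. Going by these compounds, whether it follows the whole 1H-indol-3-yl or only its hydrogen-bond donor stays open; 1-methyl-1H-indol-3-yl or benzofuran-3-yl on the same carbon would separate the two.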